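A few compounds are considered here, and "the series" means these few. Any claim that something is new, unique, unknown or untested is made for them only; others in the source may bear on it.

Measured in a functional assay on NCI-H1581 cells (Homo sapiens) for inhibition, read by MTT assay, with a stated time of 48 h, tested at 10 uM; on this read-out lower numbers stand for less inhibition and higher numbers for more inhibition at the one concentration tested (going by the name of the read-out):
compound 1 `COc1cc(NC(=O)Nc2cc(Nc3cccc(C(C)(C)C)c3)ncn2)cc(OC)c1` gives 35.1%;
compound 2 `COc1cc(NC(=O)Nc2cc(Nc3ccc(F)c(Cl)c3)ncn2)cc(OC)c1` gives 53%;
compound 3 `COc1ccc(Nc2cc(NC(=O)Nc3c(Cl)cccc3Cl)ncn2)cc1C` gives 45.1%.

Compound 3 stands second highest of the three numbers in this assay, within the scatter of both compound 2 and compound 1. Compound 4 `COc1cc(NC(=O)Nc2cc(Nc3ccc(OC)c(C)c3)ncn2)cc(OC)c1` has not yet been measured; it differs from compound 3 by 3,5-dimethoxyphenyl in place of 2,6-dichlorophenyl on an amide-type nitrogen. Going by the values given here, the only measured step, a number 17.9 percentage points higher from compound 1 to compound 2 (beyond the scatter), changes the group on the other nitrogen, so it does not bear on this change. Compounds 1 and 2 both carry the 3,5-dimethoxyphenyl that enters, and their values bracket compound 3. The step of a number 0.1 percentage points lower from compound 3 to compound 4 (within the scatter) is therefore expected to be small and of uncertain direction. Compound 4 is estimated at 45%, between 25% and 65%.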

Compound 4, a percentage reported as inhibition, at one concentration (the size of the read-out at that concentration, not a potency): 19.7%
Compound 4: the middle estimate sits 25.3 percentage points above what was measured; measured number outside the range, below it.
By their numbers in this assay, from the lowest: compound 4; then compounds 1, 3 and 2 (each within the scatter of the next, the first and the last beyond it).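

The change on the amide-type nitrogen now has a measured size in this assay: with 4-methoxy-3-methylphenyl held fixed on the other nitrogen, 3,5-dimethoxyphenyl in place of 2,6-dichlorophenyl gives a number 25.4 percentage points lower from compound 3 to compound 4 (beyond the scatter). The series with 3,5-dimethoxyphenyl also gains a third group on the nitrogen on the aromatic ring, which reads lower than both earlier groups, with a number 33.3 percentage points lower from compound 2 to compound 4 (beyond the scatter) and a number 15.4 percentage points lower from compound 1 to compound 4 (beyond the scatter).

Nothing available explains these steps. As far as these compounds go, it remains open whether the 2,6-dichlorophenyl step holds with 3-chloro-4-fluorophenyl on the other nitrogen, and how a pyridine ring on the amide-type nitrogen would read.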